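This account rests on a few compounds, and the source may have more. Where it says the series, first, only, none or still open, it means among the compounds named here.

Working notes on the series. Within the data shown here, compound 2 `O=C([C@@H]1C[C@H]1c1ccccc1)N(CC1CCCNC1)c1ccc(-c2ccccc2)cc1` gives 10 nM in a functional assay for agonist activity at G protein-coupled receptor 88 (Homo sapiens), read by HTRF and cAMP accumulation; a lower number here means that less compound is needed, a higher number that more compound is needed for the effect; of the two numbers measured so far this is the higher one, the other belonging to compound 1 `CC(C)(N)CN(C(=O)[C@@H]1C[C@H]1c1ccccc1)c1ccc(-c2ccccc2)cc1`, which in this assay gives 1.4 nM. Among the measured compounds shown here, the single measured step is a 7.1-fold higher number from compound 1 to compound 2 (0.85 log units; beyond the scatter), the cyclic secondary amine side chain of compound 2 replacing the open primary amine side chain of compound 1.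

Compound 3 `CC(C)C[C@H](N)CCN(C(=O)[C@@H]1C[C@H]1c1ccccc1)c1ccc(-c2ccccc2)cc1` is not yet measured. It differs from compound 2 by 2-amino-4-methylpentyl in place of piperidin-3-yl on a saturated chain carbon bound to an amide-type nitrogen. The change returns to an open chain carrying a primary amine, as in compound 1, but with a longer, branched chain that compound 1 does not have, so the measured step covers only part of it.

The expectation for compound 3 is therefore a step back toward the number of compound 1, of the order a 3.3-fold lower number from compound 2 to compound 3 (0.52 log units; beyond the scatter), on the basis of a 7.1-fold higher number from compound 1 to compound 2 (0.85 log units; beyond the scatter) read in reverse, but the added chain length leaves room for it to fall short. The estimate for compound 3 in this assay is 3 nM, within 0.8 nM to 12 nM.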

Compound 3, half-maximal effective concentration: 3 nM
The estimate for compound 3 equals the measured number at the digits printed; measured number inside the range.
By their numbers in this assay, from the lowest: compound 1; then compound 3; then compound 2.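

In this assay, 2-amino-4-methylpentyl in place of piperidin-3-yl gives a 3.3-fold lower number from compound 2 to compound 3 (0.52 log units; beyond the scatter) and so recovers part of the difference between the first two compounds, showing that an open chain at this position need not be limited to the short 1-amino-1-methylethyl group. The comparison with the shorter open chain gives a 2.1-fold higher number from compound 1 to compound 3 (0.33 log units; beyond the scatter) and is also beyond the scatter, so the larger open chain does not fully match 1-amino-1-methylethyl and compound 1 keeps the lowest number of the three. Nothing available gives a reason for either step, and the numbers alone do not explain the order of the three side chains.

The step from compound 2 to compound 3 removes the ring and also changes the size and branching of the side chain, so the contribution of each remains unresolved; an unbranched 2-aminopentyl chain would separate ring opening from branching. Every side chain shown carries an amine, so the need for that group remains open, and a hydroxyl group or a carboxylic acid in its place would test it directly.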